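Replacing 4-methoxyphenyl with ethyl in compound 3

A few compounds are considered here, and "the series" means these few. Any claim that something is new, unique, unknown or untested is made for them only; others in the source may bear on it.

Measured in a functional assay on MCF7 cells (Homo sapiens) for inhibition, read by MTT assay, with a stated time of 72 h; on this read-out lower numbers stand for stronger inhibition and higher numbers for weaker inhibition:
- Compound 1 `Cc1cc(Nc2cc(-c3ccccc3)[nH]n2)n2nc(SCc3ccc([N+](=O)[O-])cc3)nc2n1`: 5060 nM
- Compound 2 `Cc1cc(Nc2cc(-c3ccccc3)[nH]n2)n2nc(SCCCc3ccccc3)nc2n1`: 3900 nM
- Compound 3 `COc1ccc(CSc2nc3nc(C)cc(Nc4cc(-c5ccccc5)[nH]n4)n3n2)cc1`: 4020 nM

Compound 3 stands within the scatter of both other compounds, as shown by the step of a 1.0-fold higher number from compound 2 to compound 3 (0.01 log units; within the scatter) and the step of a 1.3-fold lower number from compound 1 to compound 3 (0.10 log units; within the scatter). The next compound is compound 4 `CCCSc1nc2nc(C)cc(Nc3cc(-c4ccccc4)[nH]n3)n2n1`, which has not yet been measured. It differs from compound 3 on a saturated chain carbon bound to a sulfur: ethyl in place of 4-methoxyphenyl on a saturated chain carbon bound to a sulfur. Cut one bond further out, this is 4-methoxybenzyl to propyl.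

The measured steps at this place are small. Phenethyl in place of 4-nitrophenyl gives the step of a 1.3-fold lower number from compound 1 to compound 2 (0.11 log units; within the scatter), and 4-methoxyphenyl in place of phenethyl gives the step of a 1.0-fold higher number from compound 2 to compound 3 (0.01 log units; within the scatter). Methoxy in place of nitro on an aromatic carbon gives the step of a 1.3-fold lower number from compound 1 to compound 3 (0.10 log units; within the scatter). All three lie within the scatter. However, every measured compound keeps an aromatic ring in this group, and ethyl brings none, so the data do not directly cover this change. No step beyond the scatter is therefore expected, though with a wide margin. The estimated change is a 1.2-fold higher number from compound 3 to compound 4 (0.08 log units; within the scatter). For compound 4 the estimated value is 4800 nM, with an expected range from 2200 nM to 10000 nM.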

Compound 4, half-maximal inhibitory concentration: > 50000 nM
Compound 4: only a limit was reported; the forecaster's own chance of this, stated with the estimate: 5%; middle value at least 10-fold (1.01 log units) from the limit.
By their numbers in this assay, from the lowest: compounds 2, 3 and 1 (each within the scatter of the next). At a limit, above all of these: compound 4.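

Compound 4 is reported in this assay only as a limit: the limit of > 50000 nM in this assay, at which 1 of the 4 values shown sits.

Set against the compounds that carry an aromatic ring in this group, the propyl group gives an at least 12-fold higher number from compound 3 to compound 4 (1.09 log units; beyond the scatter) and an at least 9.8-fold higher number from compound 1 to compound 4 (0.99 log units; beyond the scatter), while an at least 12-fold higher number from compound 2 to compound 4 (1.10 log units; beyond the scatter) comes from replacing only the phenyl with hydrogen on an otherwise unchanged chain. Among the four compounds shown, the differences between the nitro-bearing, methoxy-bearing and phenyl-ended groups stay within the scatter, so the position accommodates these variations, yet the one group without a ring stands clearly apart from all of them.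

The compounds shown leave open whether the aromatic ring itself matters or whether the number of heavy atoms in the group is enough, a question that a cyclohexylmethyl group or a longer chain such as octyl in this place would address. They also leave open how a shorter aromatic attachment, such as a plain benzyl group without a substituent, or a group carrying an amine would read out here.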